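Lengthening a Fluorinated Chain on a Shared Core

This account rests on a few compounds, and the source may have more. Where it says the series, first, only, none or still open, it means among the compounds named here.

Measured compounds:
compound 1 `FC(F)(F)C(F)(F)C(F)(F)C(F)(F)C(F)(F)C(F)(F)CCn1cc(COc2ccccc2-c2nc3ccccc3s2)nn1`: 19800 nM
compound 2 `FC(F)(F)Oc1ccc(-c2cc(COc3ccccc3-c3nc4ccccc4s3)on2)cc1`: 26600 nM
compound 3 `c1ccc(-n2cc(COc3ccccc3-c3nc4ccccc4s3)nn2)cc1`: 26200 nM

Three compounds built on the same core were tested in a functional assay on MCF7 cells (Homo sapiens) for cytotoxicity, read by MTT assay, with a stated time of 24 h; on this read-out higher numbers stand for weaker inhibition and lower numbers for stronger inhibition. Compound 1 carries the smallest of the three numbers, yet its gaps to compound 3 and to compound 2 both fall within the usual scatter of this assay, so the three cannot be separated with confidence.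

Compound 4 `FC(F)(F)C(F)(F)C(F)(F)C(F)(F)C(F)(F)C(F)(F)C(F)(F)C(F)(F)CCn1cc(COc2ccccc2-c2nc3ccccc3s2)nn1` is not yet measured. It differs from compound 1 in one place: 1,1,2,2,2-pentafluoroethyl in place of fluoro on a saturated chain carbon bound to two fluorine atoms and a saturated chain carbon. In plain words, the fluorinated chain is carried two carbons further out at its end while the rest of the molecule is unchanged.

Among the measured compounds shown here, no measured pair shows what such a lengthening does on this core, and the three known values sit close together. The step of a 1.1-fold lower number from compound 1 to compound 4 (0.04 log units; within the scatter) is therefore expected to be small, with no clear direction beyond the scatter. Compound 4 is estimated to give about 18000 nM, with a likely range from 8000 nM to 40000 nM.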

Compound 4, half-maximal inhibitory concentration: 19200 nM
The estimate for compound 4 lay 1.1-fold (0.03 log units) below the measured number; measured number inside the range.
By their numbers in this assay, from the lowest: compounds 4, 1, 3 and 2 (each within the scatter of the next).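

In this assay there is now a direct reading at the end of the fluorinated chain: the step is a 1.0-fold lower number from compound 1 to compound 4 (0.01 log units; within the scatter) when 1,1,2,2,2-pentafluoroethyl replaces fluoro on a saturated chain carbon bound to two fluorine atoms and a saturated chain carbon. Here, then, a group of 7 heavy atoms enters where 1 heavy atom leaves, and this read-out registers no change that can be told from the scatter. No further measurement bears on this result.

Going by these compounds, whether a shorter fluorinated chain, a plain hydrocarbon chain or an amine at the chain end would move the number beyond the scatter remains open. A single step also leaves open whether still longer fluorinated chains would behave the same way.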